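A few compounds are considered here, and "the series" means these few. Any claim that something is new, unique, unknown or untested is made for them only; others in the source may bear on it.

Measured compounds:
- compound 1: `COc1cc(F)c(CN2C(=O)N(c3cc(OC)nc(OC)c3)S(=O)(=O)c3ccccc32)c(F)c1` — 1 nM in an assay on isolated protein for displacement of a labelled ligand from Orexin/Hypocretin receptor type 1 (Homo sapiens), with a stated time of 90 min; on this read-out higher numbers stand for weaker inhibition and lower numbers for stronger inhibition
- compound 2: `COc1ccc(N2C(=O)N(Cc3ccc(F)cc3Cl)c3ccccc3S2(=O)=O)cc1OC` — > 2510 nM in this assay

Within the data shown here, compound 1 and compound 2 share the same kind of ring-fused core, but the groups attached to the two ring nitrogens sit in swapped positions, so no single-point step connects them. Compound 2 stands at the edge of what this assay can report: its value of > 2510 nM is a limit, not a number, and the limit of > 2510 nM in this assay, at which 1 of the 2 values shown sits, describes that. Compound 1, by contrast, gives 1 nM in this assay.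

Compound 3, `COc1ccc(N2C(=O)N(Cc3c(F)cc(F)cc3OC)c3ccccc3S2(=O)=O)cc1OC`, has not yet been measured. It differs from compound 2 in one place: 2,4-difluoro-6-methoxyphenyl in place of 2-chloro-4-fluorophenyl on a saturated chain carbon bound to an amide-type nitrogen in a ring. The structural change replaces a chlorine and adds a methoxy group on the benzyl ring, while the rest of the molecule is kept.

Among the measured compounds shown here, with compound 2 sitting at a limit, only a weak starting point is known, and no measured step of this kind exists to lean on. Compound 3 is therefore expected to remain weak, with a step from compound 2 of a step that the limit leaves unreadable from compound 2 to compound 3. The estimate for compound 3 in this assay is 3000 nM, within a range of 500 nM to 12000 nM, with a fair chance that the assay again reports only a limit.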

Compound 3, inhibition constant: 63.1 nM
Estimate against measurement, compound 3: 48-fold (1.68 log units) above, and the stated range ends above it.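

Among these compounds, the benzyl group on the amide-type nitrogen in a ring now proves to be a position where a single change has a large effect in this assay, something the earlier compounds could not show because they offered no step in one place. Replacing 2-chloro-4-fluorobenzyl with 2,4-difluoro-6-methoxybenzyl gives an at least 39-fold lower number from compound 2 to compound 3 (1.59 log units; beyond the scatter), and compound 3 has a true measured value, so changes can now be followed from it as numbers. Compound 2 gives > 2510 nM, which is a limit, so the step from it sets only a minimum size, and the full size of the change cannot be read: the limit of > 2510 nM in this assay, at which 1 of the 3 values shown sits.

The change does two things at once, exchanging a chlorine for a fluorine and adding a methoxy group, and the compounds shown cannot separate what each contributes to the step. From the compounds shown here alone, it also remains open whether an ethoxy or a hydroxyl group in place of that methoxy would hold the inhibition seen with compound 3, and whether this benzyl change gives a similar step when the other ring nitrogen carries a different group.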